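A second fluorine on the tethered ring: an estimate

This account rests on a few compounds, and the source may have more. Where it says the series, first, only, none or still open, it means among the compounds named here.

compound 1 `c1ccc(COc2nc3ccccc3s2)cc1`: 68.8%
compound 2 `Fc1ccc(COc2nc3ccccc3s2)cc1`: 90.7%
compound 3 `Fc1ccc(OCCOc2nc3ccccc3s2)cc1`: 72.7%

Of the compounds shown here, three sharing a core have been tested in a functional assay on the whole organism with Mus musculus as the target, with a stated time of 1 h, at a dose of 100 mg/kg by the intraperitoneal route (on this read-out higher numbers stand for more inhibition at the one dose given (going by the name of the read-out) and lower numbers for less inhibition), and a fourth, compound 4 `Fc1ccc(OCCOc2nc3ccccc3s2)c(F)c1`, has not. Within the data shown here, the one counted step among the measured compounds is a number 21.9 percentage points higher from compound 1 to compound 2 (beyond the scatter), the change being (fluoro in place of hydrogen on an aromatic carbon). Compound 3 has a different, longer link between the two ring systems than compound 1; the difference between these two cores is not broken down here. In this assay compound 3 gives a figure that sits close to that of compound 1 and below that of compound 2.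

Compound 4 arises from compound 3 by fluoro in place of hydrogen on an aromatic carbon. Among the measured compounds shown here, this is the same kind of change as the one from compound 1 to compound 2, but the surroundings are not the same: in compound 2 the new fluoro group stands para to a large group, whereas in compound 4 it stands ortho to a large group and meta to a fluoro group, on a ring that already carries one fluorine. For the measured compounds named here, since the only measured precedent is the step from compound 1 to compound 2, the expected step is taken in the same direction but smaller, estimated as a number 7.3 percentage points higher from compound 3 to compound 4 (within the scatter). Because compound 3 gives 72.7%, compound 4 is estimated at 80%, within a range from 62% to 95%.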

Compound 4, a percentage reported as inhibition, in the whole organism at one dose (the size of the read-out at that dose, not a potency): 56.1%
Compound 4: the middle estimate sits 23.9 percentage points above what was measured, outside the stated range (below it).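

In this assay the fluoro group on the core of compound 3 gives a number 16.6 percentage points lower from compound 3 to compound 4 (beyond the scatter) and so runs against the earlier result on the other core, which was a number 21.9 percentage points higher from compound 1 to compound 2 (beyond the scatter) in the same read-out. The same change therefore does not carry its direction from one core to the other in this series, and the gain seen on the core of compound 1 cannot be assumed on the longer link: the same change on two cores in this assay, a number 21.9 percentage points higher (beyond the scatter) from compound 1 to compound 2 and a number 16.6 percentage points lower (beyond the scatter) from compound 3 to compound 4, 38.5 percentage points apart, beyond the scatter of two such steps.

This does not show what lies behind the difference, since the two steps differ both in the core and in the place of the new fluoro group, which in compound 4 stands ortho to a large group and meta to a fluoro group, and a single pair on each core cannot separate these two, nor does it set a rule beyond these four compounds.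

The compounds shown leave open whether the drop belongs to the longer link or to the place on the ring, as none of them carries a fluoro group ortho to a large group on the core of compound 1. On these data alone, it also stays open whether a chloro or a methoxy group in that same place would go the way of fluoro.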